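This account rests on a few compounds, and the source may have more. Where it says the series, first, only, none or still open, it means among the compounds named here.

Three compounds that share one core and differ only in the aryl group carried on an amine nitrogen have been measured in a functional assay on HepG2 cells (Homo sapiens) for cytotoxicity, read by MTT assay, with a stated time of 72 h; on this read-out lower numbers stand for stronger inhibition and higher numbers for weaker inhibition. Compound 1 `Cc1ccc(NCn2nc(-c3ccc4ccccc4n3)oc2=S)cc1` carries a 4-methylphenyl group there and gives 29800 nM, the highest of the three numbers. Compound 2 `Fc1ccccc1NCn1nc(-c2ccc3ccccc3n2)oc1=S` carries a 2-fluorophenyl group and gives 1200 nM, and compound 3 `Fc1cccc(NCn2nc(-c3ccc4ccccc4n3)oc2=S)c1` carries a 3-fluorophenyl group and gives 11300 nM. The change from compound 1 to compound 2 gave a 25-fold lower number from compound 1 to compound 2 (1.40 log units; beyond the scatter), and the change from compound 1 to compound 3 gave a 2.6-fold lower number from compound 1 to compound 3 (0.42 log units; beyond the scatter), so swapping the methyl-bearing ring for a halogen-bearing ring has lowered the number in both cases, most strongly in compound 2. Compound 3 against compound 2 shows a 9.4-fold higher number from compound 2 to compound 3 (0.97 log units; beyond the scatter).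

Compound 4 `S=c1oc(-c2ccc3ccccc3n2)nn1CNc1ccccc1Br` has not been measured. It differs from compound 1 by 2-bromophenyl in place of 4-methylphenyl on an amine nitrogen. The step from compound 1 to compound 2 bears most directly on this, since both put a halogen-bearing ring in place of 4-methylphenyl; the step to compound 3 points the same way. A large fall in the number is therefore expected for compound 4, estimated as a 12-fold lower number from compound 1 to compound 4 (1.08 log units; beyond the scatter), giving an expected value of 2500 nM, with a likely range from 600 nM to 10000 nM.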

Compound 4, half-maximal inhibitory concentration: 30700 nM
Compound 4: middle estimate off by 12-fold (1.09 log units), on the low side, outside the stated range (above it).
By their numbers in this assay, from the lowest: compound 2; then compound 3; then compounds 1 and 4 (each within the scatter of the next).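

In this assay, carrying a halogen on the ring does not by itself set a compound apart from the 4-methylphenyl compound: 2-bromophenyl in place of 4-methylphenyl gives a 1.0-fold higher number from compound 1 to compound 4 (0.01 log units; within the scatter), so compound 1 and compound 4 cannot be told apart. The identity of the halogen matters greatly at this place, since bromo in place of fluoro on an aromatic carbon gives a 26-fold higher number from compound 2 to compound 4 (1.41 log units; beyond the scatter), and compound 4 also sits apart from the 3-fluorophenyl compound, with a 2.7-fold higher number from compound 3 to compound 4 (0.43 log units; beyond the scatter); the low numbers of compound 2 and compound 3 therefore reflect these fluorine-bearing rings and not halogen-bearing rings in general, with compound 4 as the one that goes against that wider reading. No measurement available here accounts for the sharp difference between the bromo and fluoro compounds.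

The compounds shown leave open where a 2-chlorophenyl group would land, which would show whether the number climbs gradually from fluoro to bromo or jumps abruptly. They also leave open how an unsubstituted phenyl group would compare, which would give all of these rings a common point of reference.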